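Removing a methoxy group from the phenyl ring of compound 1

The compounds below may be only part of what the source reports. "The series", "measured", "known", "first", "only" and "open" are said of these compounds alone.

Compound 1 `COc1ccc(-n2cc3nc(-c4cccnc4C)n(C[C@H]4CCCN(C[C@H]5CCCO5)C4)c(=O)c3n2)cc1` was tested in an assay on HEK293 cells for displacement of a labelled ligand from growth hormone secretagogue receptor type 1 (Homo sapiens), with a stated time of 60 min (on this read-out higher numbers stand for weaker inhibition and lower numbers for stronger inhibition), where compound 1 gives 52 nM. Among the three measured compounds it stands second highest. Compound 2 `COc1cccc(-n2cc3nc(-c4cccnc4C)n(C[C@H]4CCCN(CC5CCC5)C4)c(=O)c3n2)c1` gives 1.6 nM, and compound 3 `COc1cccc(-n2cc3nc(-c4cccnc4C)n(C[C@H]4CCCN(CC5CCOC5)C4)c(=O)c3n2)c1` gives 60 nM. The values of compound 1 and compound 3 lie within the scatter of each other, while compound 2 sits well apart from both.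

Compound 4 `Cc1ncccc1-c1nc2cn(-c3ccccc3)nc2c(=O)n1C[C@H]1CCCN(C[C@H]2CCCO2)C1` has not yet been measured. It differs from compound 1 by hydrogen in place of methoxy on an aromatic carbon, which, cut one bond further out, reads 4-methoxyphenyl to phenyl.

For the measured compounds named here, the only measured step that differs in one place is a 38-fold higher number from compound 2 to compound 3 (1.57 log units; beyond the scatter), a change on the saturated chain carbon bound to the ring amine nitrogen, not on the aromatic ring. Going by the values given here, no measured pair isolates the loss of a methoxy from the phenyl ring, so there is no direct guide to the size or direction of the step to compound 4. The expectation is therefore a step of about a 1.2-fold higher number from compound 1 to compound 4 (0.06 log units; within the scatter), not beyond the scatter, with a wide range. Compound 4 is estimated at 60 nM, between 15 nM and 250 nM.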

Compound 4, half-maximal inhibitory concentration: 190 nM
Estimate against measurement, compound 4: 3.2-fold (0.50 log units) below, within the range that was stated.
By their numbers in this assay, from the lowest: compound 2; then compounds 1 and 3 (each within the scatter of the next); then compound 4.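

In this assay, for the compounds shown here, the loss of methoxy from an aromatic carbon, para to a large group, gives a 3.7-fold higher number from compound 1 to compound 4 (0.56 log units; beyond the scatter) and this is the first measured sign that the phenyl ring affects the number, since the only earlier step lay on the saturated chain carbon bound to the ring amine nitrogen. The change is small in atoms, with only a methoxy replaced by hydrogen, yet it lies beyond the scatter and goes towards weaker inhibition, so within this pair the methoxy-bearing compound 1 is the stronger inhibitor. No measurement shown here accounts for this step.

Compounds 2 and 3 carry their methoxy at another place on the phenyl ring, but they also differ from compound 1 in the chain on the ring amine nitrogen, so no pair shown isolates the place of the methoxy on the ring. Also open, on these data alone, are how a fluorine atom, a hydroxyl or an ethoxy would compare at this carbon, and whether removing the methoxy would give a step of similar size alongside the cyclobutyl chain of compound 2.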